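Cytotoxicity read-out across four analogues of one series

This account rests on a few compounds, and the source may have more. Where it says the series, first, only, none or still open, it means among the compounds named here.

The series is read in an ADME assay on CHO cells (Cricetulus griseus) for cytotoxicity, read by MTT assay; on this read-out lower numbers stand for stronger inhibition and higher numbers for weaker inhibition. Compound 1 `Cc1cc(C)n(-c2cc(-c3ccccc3)cc(=O)n2C)n1` gives only a limit in this assay, > 50000 nM. Compound 2 `O=c1cc(-c2ccccc2)nc(-n2cccn2)[nH]1` likewise reaches only the limit, > 50000 nM. Compound 3 `CCOc1cc(C)nn1-c1nc(C(F)(F)F)cc(=O)[nH]1` also stops at the limit, > 50000 nM. For the measured compounds named here, no pair of these three differs in a single place, so no step is counted between them; all the numbers show is that each of them sits at the same limit, (the limit of > 50000 nM in this assay, at which 3 of the 3 values shown sit), and nothing in this assay separates compound 3 from compound 1 or compound 2.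

Compound 4 `Cc1cc(Nc2ccccn2)n(-c2nc(C(F)(F)F)cc(=O)[nH]2)n1` is the next compound to be measured in this assay. It differs from compound 3 by (pyridin-2-yl)amino in place of ethoxy on an aromatic carbon. Going by the values given here, with no measured step to draw on and all three values shown resting at the limit, the expectation is that this change moves the read-out by no amount beyond the scatter, a step that the limit leaves unreadable from compound 3 to compound 4. Compound 4 is accordingly expected to return a reading of about 60000 nM, with a range from 20000 nM to 200000 nM, and most probably again only a limit rather than a number.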

Compound 4, half-maximal inhibitory concentration: 23000 nM
Beside the measured number, compound 4's estimate is 2.6-fold (0.42 log units) above it; the range from low to high includes it.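

In this assay, placing (pyridin-2-yl)amino instead of ethoxy on the aromatic carbon next to the ring nitrogen gives an at least 2.1-fold lower number from compound 3 to compound 4 (0.33 log units; beyond the scatter), and compound 4 holds the only reading among the compounds shown that is a number rather than a limit. For compound 3, the value > 50000 nM is a limit, so the step gives only a minimum size and the full size cannot be read. This pair is the only single-place comparison in the set, and it shows that a change at this position on the five-membered aromatic ring can bring the read-out to a measurable number, which the other values could not show: the limit of > 50000 nM in this assay, at which 3 of the 4 values shown sit.

One step leaves open whether the lower number goes with the pyridine ring, with its ring nitrogen or with the linking amino group, and a phenylamino group or a plain amine on the same aromatic carbon would help separate these. As far as these compounds go, it also remains open whether (pyridin-2-yl)amino would have a similar effect on the core of compound 1 or compound 2, or whether a longer alkoxy chain at this position would change the read-out at all.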